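Replacing the 1H-pyrazol-5-yl group of compound 2

A few compounds are considered here, and "the series" means these few. Any claim that something is new, unique, unknown or untested is made for them only; others in the source may bear on it.

Compound 1 `CCCCc1nc(C(C)(C)C)nc2nc(N)c(C#N)c(N)c12` gives 6000 nM
Compound 2 `CC(C)(C)c1nc(-c2ccn[nH]2)c2c(N)c(C#N)c(N)nc2n1` gives 13500 nM

Both numbers come from a physicochemical assay for solubility, in phosphate buffer, with a stated time of 18 h (on this read-out higher numbers stand for higher solubility and lower numbers for lower solubility), and compound 2 holds the higher of the two at 13500 nM in this small set. Compound 3 `CC(C)(C)c1nc(-c2nc(CO)cs2)c2c(N)c(C#N)c(N)nc2n1` has not yet been measured. It carries 4-(hydroxymethyl)-1,3-thiazol-2-yl in place of 1H-pyrazol-5-yl on an aromatic carbon, and the change is 4-(hydroxymethyl)-1,3-thiazol-2-yl in place of 1H-pyrazol-5-yl on an aromatic carbon in full. Within the data shown here, only one measured step bears on this place, where putting 1H-pyrazol-5-yl in place of butyl gave a 2.3-fold higher number from compound 1 to compound 2 (0.35 log units; beyond the scatter) as a modest change. That step involves a different pair of groups, so it is only a rough guide to size. A small downward step, not beyond the scatter, is expected in this assay and the estimate is a 1.5-fold lower number from compound 2 to compound 3 (0.18 log units; within the scatter) for now. The estimate for compound 3 is 9000 nM with an expected range from 3000 nM to 25000 nM in this read-out.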

Compound 3, solubility: < 1000 nM
Compound 3: no number, only a limit; the forecaster's own chance of this, stated with the estimate: 5%; middle value at least 9.0-fold (0.95 log units) away from the limit.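

Compound 3 gives no number in this assay, only a limit: the limit of < 1000 nM in this assay, at which 1 of the 3 values shown sits. Exchanging 1H-pyrazol-5-yl for 4-(hydroxymethyl)-1,3-thiazol-2-yl gives an at least 13-fold lower number from compound 2 to compound 3 (1.13 log units; beyond the scatter), so the read-out at this place depends strongly on which group is attached, even though each carries one five-membered aromatic ring with 2 hetero atoms. Exchanging butyl for the same group gives an at least 6.0-fold lower number from compound 1 to compound 3 (0.77 log units; beyond the scatter), so an aromatic ring here does not go with higher numbers across the set: compound 2 fits that idea, while compound 3 goes against it.

The ring and its hydroxymethyl group enter together, so the compounds shown cannot say which of the two goes with the drop. A plain 1,3-thiazol-2-yl group, or a pyrazole ring carrying hydroxymethyl, would separate the two, and the full size of the drop stays hidden behind the limit.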